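The source may report more compounds than this note shows. Statements on the series, on what has been measured and on what is new or still open speak of the compounds shown alone.

In a functional assay on the whole organism (Tail, strain ICR) with Mus musculus as the target, in the tail flick test, with a stated time of 60 min, at a dose of 25 umol/kg by the oral route (on this read-out lower numbers stand for a weaker effect and higher numbers for a stronger effect at the one dose given), compound 1 `C[C@H](NC(=O)CN(c1nc(Cl)nc2[nH]cnc12)C1CC1)C(=O)OCc1ccccc1` gives 64.3%, and compound 2 `CC[C@H](C)[C@H](NC(=O)CN(c1ncnc2c1ncn2C1CCCCO1)C1CC1)C(=O)OCc1ccccc1` gives 27.4%, the lower of the two numbers, with compound 1 standing beyond the scatter above it. Compound 3 `CSCC[C@H](NC(=O)CN(c1ncnc2c1ncn2C1CCCCO1)C1CC1)C(=O)OCc1ccccc1` is not yet measured. It differs from compound 2 in one place: 2-(methylsulfanyl)ethyl in place of sec-butyl on a saturated chain carbon bound to an amide-type nitrogen and a carbonyl carbon. Within the data shown here, no measured pair shows the effect of this kind of change on its own, so compound 3 is expected to stay close to compound 2, the estimated step of a number 2.6 percentage points higher from compound 2 to compound 3 (within the scatter) being none beyond the scatter. For compound 3 the expected value is 30%, with a range from 10% to 55%.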

Compound 3, a percentage reported as activity, at one dose (the size of the read-out at that dose, not a potency): 41%
Estimate against measurement, compound 3: 11 percentage points below; the range from low to high includes it.
By their numbers in this assay, from the lowest: compound 2; then compound 3; then compound 1.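

In this assay, the change of side chain gives a number 13.6 percentage points higher from compound 2 to compound 3 (beyond the scatter), a modest step. Among these compounds, this is the first one-place comparison, and it shows that the read-out responds to this side chain even when the count of 4 heavy atoms stays the same. No available evidence bears on the reason for the step. Going by these compounds, whether the sulfur itself matters remains open, since an unbranched butyl chain does not appear here. On these data alone, how an amine or a carboxylic acid at this position would read is also open.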